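The source may hold more compounds than are shown below. What is called first, only, known or untested is meant among the compounds shown, and "the series" means these compounds.

Measured so far:
compound 1 `CC(C)(C)C1=C(C(=O)O)N2C(=O)[C@H]([C@H](O)c3ccccc3)[C@H]2O1`: 7 h
compound 2 `CC(C)(C)C1=C(C(=O)O)N2C(=O)[C@H](CO)[C@@H]2O1`: 2.4 h
compound 3 `C[C@@H](O)[C@H]1C(=O)N2C(C(=O)O)=C(C(C)(C)C)O[C@@H]12`: 6.4 h

In an ADME assay, in phosphate buffer, at 28 degrees C, at pH 7.0 (a higher number here means that the compound lasts longer, a lower number that the compound disappears faster), compound 3 stands second highest of the three: compound 1 gives a number within the scatter of it, compound 2 a clearly lower one. Compound 4 `CC(C)(C)C1=C(C(=O)O)N2C(=O)[C@H]([C@H](O)c3ccccc3)[C@@H]2O1` differs from compound 3 by phenyl in place of methyl on a saturated chain carbon bound to an oxygen on a saturated carbon and a saturated ring carbon. Going by the values given here, no measured pair shows this exact exchange. The step that bears on the same place is a 2.7-fold higher number from compound 2 to compound 3 (0.43 log units; beyond the scatter), a modest gain from a methyl where hydrogen had been. The phenyl of compound 4 is also found in compound 1, which gives 7 h; compound 2, with hydrogen at that place, gives 2.4 h. Compound 4 is therefore expected to change little, a 1.1-fold higher number from compound 3 to compound 4 (0.04 log units; within the scatter). The estimate for compound 4 is 7 h, range 3.5 h to 14 h.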

Compound 4, half-life: 0.5 h
Estimate against measurement, compound 4: 14-fold (1.15 log units) above; the measured number lies below the stated range.
By their numbers in this assay, from the lowest: compound 4; then compound 2; then compounds 3 and 1 (each within the scatter of the next).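

In this assay phenyl alone does not fix the number at this place, since the drawn configuration at a saturated ring carbon carries a 14-fold lower number from compound 1 to compound 4 (1.15 log units; beyond the scatter), and the cause can lie only there: the fact that compounds 1 and 4 differ only in the configuration as drawn. With the configuration of compound 4, phenyl in place of methyl gives a 13-fold lower number from compound 3 to compound 4 (1.11 log units; beyond the scatter), and phenyl in place of hydrogen gives a 4.8-fold lower number from compound 2 to compound 4 (0.68 log units; beyond the scatter). The gain from methyl in place of hydrogen therefore does not extend to phenyl in this configuration.

As far as these compounds go, the effect of an amine or a longer chain in place of phenyl remains open. So does whether the configuration gap recurs with methyl in place of phenyl.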